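This account rests on a few compounds, and the source may have more. Where it says the series, first, only, none or still open, it means among the compounds named here.

In an ADME assay on HFF cells (Homo sapiens) for cytotoxicity, with a stated time of 8 days (on this read-out lower numbers stand for higher toxicity in this test and higher numbers for lower toxicity in this test), compound 1 `CCCSc1nc(N)nc2c1ncn2/C=C1/CC1(CO)CO` reaches only a limit of the test, giving > 300000 nM. Compound 2 `CC(C)Nc1nc(N)nc2c1ncn2/C=C1/CC1(CO)CO` likewise sits at a limit, with > 300000 nM. Compound 3 `Nc1nc(N2CCCC2)c2ncn(/C=C3/CC3(CO)CO)c2n1` also stops at a limit, at > 300000 nM. The three steps among them, a step that the two limits leave unreadable from compound 1 to compound 2, a step that the two limits leave unreadable from compound 1 to compound 3 and a step that the two limits leave unreadable from compound 2 to compound 3, carry no readable size, due to the limit of > 300000 nM in this assay, at which 3 of the 3 values shown sit. Compound 4 `CCCOc1nc(N)nc2c1ncn2/C=C1/CC1(CO)CO` differs from compound 3 by propoxy in place of pyrrolidin-1-yl on an aromatic carbon. Among the measured compounds shown here, no measured step bears readably on this change; what is known is only that none of the three changes so far brought toxicity into the measured range. Compound 4 is therefore expected to stay at the limit as well, with an estimate of 300000 nM and a range from 100000 nM to 1000000 nM. The expected step is then a number no higher from compound 3 to compound 4 (the limit leaves the size open).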

Compound 4, half-maximal cytotoxic concentration: > 300000 nM
Compound 4 gave a limit, no number; the forecaster's own chance of this, stated with the estimate: 85%; the middle value sits exactly at the limit.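

No size can be read for the steps from compound 1, compound 2 or compound 3 to compound 4, due to one shared limit: the limit of > 300000 nM in this assay, at which 4 of the 4 values shown sit.

The compounds shown leave open whether swapping these groups changes toxicity at all in this assay.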